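The source may hold more compounds than are shown below. What is called first, only, known or untested is meant among the compounds shown, and "the series" means these compounds.

Measured so far in a functional assay on DLD-1 cells (Homo sapiens) for antiproliferative activity, read by CellTiter-Glo, with a stated time of 72 h; a lower number here means a stronger inhibitor, a higher number a weaker inhibitor:
compound 1 `CC1CCN(C2CCN(S(=O)(=O)c3cccnc3Cl)CC2)CC1`: > 5000 nM, a limit of the assay
compound 2 `CC1CCN(C2CCN(S(=O)(=O)c3cccc(N)c3)CC2)CC1`: 3400 nM
compound 3 `CC1CCN(C2CCN(S(=O)(=O)c3ccccc3Br)CC2)CC1`: 3 nM

Compound 3 holds the lowest of the two numbers; the nearest is compound 2, with a 1100-fold lower number from compound 2 to compound 3 (3.05 log units; beyond the scatter). Compound 4 `CC1CCN(C2CCN(S(=O)(=O)c3cccnc3F)CC2)CC1` is not yet measured. It differs from compound 3 by 2-fluoropyridin-3-yl in place of 2-bromophenyl on a sulfonyl sulfur. The measured step that bears on this is an at least 1600-fold lower number from compound 1 to compound 3 (3.22 log units; beyond the scatter), which runs the opposite way between 2-chloropyridin-3-yl and 2-bromophenyl, with compound 1 sitting at the limit of > 5000 nM in this assay, at which 1 of the 3 values shown sits. Returning from 2-bromophenyl to a 2-fluoropyridin-3-yl is therefore expected to raise the number in this assay by a large margin, possibly back to the limit. Compound 4 is expected at 3000 nM, in the range 300 nM to 15000 nM, an estimated step of a 1000-fold higher number from compound 3 to compound 4 (3.00 log units; beyond the scatter).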

Compound 4, half-maximal inhibitory concentration: > 5000 nM
Compound 4 was reported as a limit; the forecaster's own chance of this, stated with the estimate: 40%; middle value at least 1.6-fold (0.22 log units) from the limit.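

In this assay, replacing 2-bromophenyl with 2-fluoropyridin-3-yl gives an at least 1600-fold higher number from compound 3 to compound 4 (3.22 log units; beyond the scatter), so the large loss seen with 2-chloropyridin-3-yl on the sulfonyl sulfur is not confined to the chloro group. Against 3-aminophenyl, the change gives an at least 1.4-fold higher number from compound 2 to compound 4 (0.16 log units; that floor lies within the scatter), which leaves those two compounds unseparated. The step from compound 1 to compound 4, both reported as limits of the assay, cannot be read: the limit of > 5000 nM in this assay, at which 2 of the 4 values shown sit.

Open, from the compounds shown here alone, is whether the ring nitrogen or the halogen accounts for the step from 2-bromophenyl, since both change together in compound 4. A 2-fluorophenyl or 2-bromopyridin-3-yl group on the same sulfur would separate the two.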